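This account rests on a few compounds, and the source may have more. Where it says the series, first, only, none or still open, it means among the compounds named here.

Working notes on the series. Two compounds have numbers in a functional assay on A549 cells (Homo sapiens) for inhibition, read by CCK-8 assay, with a stated time of 72 h, tested at 1 uM; on this read-out lower numbers stand for less inhibition of growth and higher numbers for more inhibition of growth at the one concentration tested. Compound 1 `Nc1ccc(NC(=O)C2(C(=O)Nc3ccc(F)cc3)CC2)cc1F` is the smaller amide pair without the larger core; in this assay compound 1 gives 16.3%. Compound 2 `CN(C)C(=O)c1cc2cnc(Nc3ccc(NC(=O)C4(C(=O)Nc5ccc(Cl)c(C(F)(F)F)c5)CC4)cc3)nc2n1C1CCCC1` carries the shared core; in this assay compound 2 gives 1.1%. Compound 2 stands lowest of the two numbers; the nearest is compound 1, and the gap between the two lies beyond the usual scatter.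

Compound 3 `CN(C)C(=O)c1cc2cnc(Nc3ccc(NC(=O)C4(C(=O)Nc5ccc(C#N)cc5)CC4)cc3)nc2n1C1CCCC1` has not been measured. It differs from compound 2 in one place: 4-cyanophenyl in place of 4-chloro-3-(trifluoromethyl)phenyl on an amide-type nitrogen. The change sits on an amide-type nitrogen whose other neighbour is a carbonyl carbon. For the measured compounds named here, no pair of measured compounds shows this change, so no measured step can be drawn on. Going by the values given here, the only guide is that compound 2 gives 1.1% in this assay, close to no inhibition at the single concentration. The expected step is a number 3.9 percentage points higher from compound 2 to compound 3 (within the scatter), upward only slightly and not beyond the scatter. Compound 3 is estimated at 5%, with a range of -8% to 20%.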

Compound 3, percent growth inhibition at one concentration: 86.1%
The estimate for compound 3 lay 81.1 percentage points below the measured number; the whole stated range lies below it.
By their numbers in this assay, from the lowest: compound 2; then compound 1; then compound 3.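

In this assay, the group on the amide-type nitrogen whose other neighbour is a carbonyl carbon has a large bearing on the read-out: 4-cyanophenyl in place of 4-chloro-3-(trifluoromethyl)phenyl gives a number 85 percentage points higher from compound 2 to compound 3 (beyond the scatter) on the same shared core. The near absence of inhibition seen for compound 2 is therefore not fixed by that core, and this one place is enough to separate a near-blank compound from a clearly inhibiting one at the single concentration tested. No measurement at hand explains the size of the step.

The exchange removes the chlorine and the trifluoromethyl together and brings in the nitrile, so the compounds shown do not separate the loss of either group from the gain of the nitrile. Going by these compounds, an unsubstituted phenyl, a phenyl carrying the chlorine alone or the trifluoromethyl alone, and a phenyl carrying a methoxy group at this place would address that question, while the response of compound 3 at other concentrations also remains open.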